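Will a ring return the number to compound 1's level?

The compounds below may be only part of what the source reports. "The series", "measured", "known", "first", "only" and "open" are said of these compounds alone.

- compound 1 `CCOC(=O)[C@@H]1CCCN(S(=O)(=O)c2ccc(S(=O)(=O)N3CCOCC3)cc2)C1` 23500 nM
- compound 2 `CCOC(=O)[C@@H]1CCCN(S(=O)(=O)c2ccc(S(=O)(=O)N3CCCCC3)cc2)C1` 2900 nM
- compound 3 `CCOC(=O)[C@@H]1CCCN(S(=O)(=O)c2ccc(S(=N)(=O)N(CC)CC)cc2)C1` 2600 nM

In a functional assay on MIA PaCa-2 cells (Homo sapiens) for inhibition, read by MTT assay, with a stated time of 7 days (on this read-out lower numbers stand for stronger inhibition and higher numbers for weaker inhibition), compound 3 gives 2600 nM and shares the low end of these numbers with compound 2 (a 1.1-fold lower number from compound 2 to compound 3 (0.05 log units; within the scatter)). Compound 1 lies clearly higher.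

The unmeasured compound 4 `CCOC(=O)[C@@H]1CCCN(S(=O)(=O)c2ccc(S(=O)(=O)N3CCNCC3)cc2)C1` differs from compound 3 in one place, on an aromatic carbon, where (piperazin-1-yl)sulfonyl enters (a group of 9 heavy atoms (4 carbon, 2 nitrogen, 2 oxygen, 1 sulfur; one six-membered non-aromatic ring with 2 hetero atoms) in place of a group of 8 heavy atoms (4 carbon, 2 nitrogen, 1 oxygen, 1 sulfur; no ring), on an aromatic carbon). Among the measured compounds shown here, no measured step makes this exact change. The nearest guide is compound 1, which also carries a six-membered non-aromatic ring with 2 hetero atoms. The two steps away from compound 1 are similar in size and go the same way (an 8.1-fold lower number from compound 1 to compound 2 (0.91 log units; beyond the scatter); a 9.0-fold lower number from compound 1 to compound 3 (0.96 log units; beyond the scatter)). A clear rise is therefore expected on going to compound 4, perhaps a little smaller than those steps, although this rests on compound 1 alone and its ring is not the same as the entering one.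

The expected step is upward (a 4.6-fold higher number from compound 3 to compound 4 (0.66 log units; beyond the scatter)). Compound 4 is estimated at 12000 nM, with an expected range from 4000 nM to 40000 nM.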

Compound 4, half-maximal inhibitory concentration: > 30000 nM
Compound 4: no number, only a limit (the forecaster's own chance of this, stated with the estimate: 10%); middle value at least 2.5-fold (0.39 log units) away from the limit.
By their numbers in this assay, from the lowest: compounds 3 and 2 (each within the scatter of the next); then compound 1. At a limit, above all of these: compound 4.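

Compound 4 carries no number in this assay, only a limit: the limit of > 30000 nM in this assay, at which 1 of the 4 values shown sits.

A ring on the sulfonyl sulfur does not decide the result alone: piperazin-1-yl in place of piperidin-1-yl gives a large rise (an at least 10-fold higher number from compound 2 to compound 4 (1.01 log units; beyond the scatter)), although both groups are six-membered rings. The open-chain group of compound 3 also lies far from the piperazin-1-yl group (an at least 11-fold higher number from compound 3 to compound 4 (1.06 log units; beyond the scatter)), so among these compounds the two rings with a second hetero atom, in compound 1 and compound 4, stand at the high end, while the ring of compound 2, with one hetero atom, and the open chain of compound 3 stand low. Piperazin-1-yl in place of morpholin-4-yl gives a step (an at least 1.2-fold higher number from compound 1 to compound 4 (0.10 log units; that floor lies within the scatter)) that does not separate these two rings.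

On these data alone, it remains open whether a methyl group on the ring nitrogen of piperazin-1-yl would change this picture. As far as these compounds go, it is also open whether a smaller ring with one hetero atom, such as pyrrolidin-1-yl, would stay close to compound 2.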